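This account rests on a few compounds, and the source may have more. Where it says the series, first, only, none or still open, it means among the compounds named here.

Working notes on the series. Among the measured compounds shown here, in a physicochemical assay for acid dissociation, compound 3 `COc1ccc(Oc2ccc3c(NCCCNCc4ccco4)ccnc3c2)cc1` gives 9.28; this is the smallest of the three numbers so far, yet the separations are slight. Compound 1 `FC(F)(F)c1ccc(-c2ccc3c(NCCCNCc4ccco4)ccnc3c2)cc1` gives 9.47 and compound 2 `CCC(CC)c1ccc2c(NCCCNCc3ccco3)ccnc2c1` gives 9.47; the steps of no change at the digits printed from compound 1 to compound 2 (within the scatter), a number 0.19 log units lower from compound 1 to compound 3 (within the scatter) and a number 0.19 log units lower from compound 2 to compound 3 (within the scatter) all stay inside the usual scatter, so the substituent on that aromatic carbon has not moved the read-out so far. Compound 4 `c1coc(CNCCCNc2ccnc3cc(-c4cccc5ccccc45)ccc23)c1` differs from compound 3 by naphthalen-1-yl in place of 4-methoxyphenoxy on an aromatic carbon. Nothing among the measured steps gives a reason to expect a shift beyond the scatter here. The expected value for compound 4 in this assay is 9.4, range 9.1 to 9.7, meaning an expected step of a number 0.12 log units higher from compound 3 to compound 4 (within the scatter).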

Compound 4, acid dissociation constant: 9.47
The estimate for compound 4 lay 0.07 log units below the measured number; the measured number falls inside the stated range.
By their numbers in this assay, from the lowest: compounds 3, 1, 2 and 4 (each within the scatter of the next).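

In this assay naphthalen-1-yl, with two six-membered aromatic rings of carbon only, gives a number 0.19 log units higher from compound 3 to compound 4 (within the scatter) against 4-methoxyphenoxy, no change at the digits printed from compound 2 to compound 4 (within the scatter) against pentan-3-yl and no change at the digits printed from compound 1 to compound 4 (within the scatter) against 4-(trifluoromethyl)phenyl. Among the compounds shown here, the flat read-out on this aromatic carbon therefore now extends to a group of two aromatic rings, with compound 4 going against no earlier compound. Nothing at hand explains this flatness. Still open, going by these compounds, is whether an amine or a carboxylic acid on this aromatic carbon would leave the number equally unmoved.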